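The source may report more compounds than this note shows. Statements on the series, on what has been measured and on what is new or still open speak of the compounds shown alone.

Measured compounds:
- compound 1 `N#Cc1ccc(-c2cc(-c3ccc(C(N)=O)cc3)cc(-c3ccco3)n2)cc1` — a physicochemical assay for solubility, at pH 6 (on this read-out higher numbers stand for higher solubility and lower numbers for lower solubility), 10000 nM
- compound 2 `N#Cc1ccc(-c2cc(-c3ccc(C(N)=O)cc3)cc(-c3cnco3)n2)cc1` — this assay 250000 nM
- compound 3 `Cn1ccnc1-c1cc(-c2ccc(C(N)=O)cc2)cc(-c2ccc(C#N)cc2)n1` — this assay 8000 nM

Compound 3 gives the lowest of the three numbers in this assay. Its nearest neighbour is compound 1, since a 1.3-fold lower number from compound 1 to compound 3 (0.10 log units; within the scatter); its furthest is compound 2, since a 31-fold lower number from compound 2 to compound 3 (1.49 log units; beyond the scatter). Against compound 1 the imidazole and the furan are therefore not separated by the measurement, whereas the oxazole in compound 2 stands clearly apart from both.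

Compound 4 `N#Cc1ccc(-c2cc(-c3ccc(C(N)=O)cc3)cc(-c3cccc(F)c3)n2)cc1` is compound 3 with 3-fluorophenyl in place of 1-methyl-1H-imidazol-2-yl on an aromatic carbon. For the measured compounds named here, no measured step brings in a six-membered ring of carbon only at this position, so the two steps that touch the imidazole of compound 3 are the only guide: a 1.3-fold lower number from compound 1 to compound 3 (0.10 log units; within the scatter), which was within the scatter, and a 31-fold lower number from compound 2 to compound 3 (1.49 log units; beyond the scatter), which was large. The change to compound 4 removes the ring with two hetero atoms and zero hydrogen-bond acceptors enter in its place, a move in the direction away from the oxazole of compound 2 rather than toward it, so the expectation for compound 4 in this assay is a step of a 1.6-fold lower number from compound 3 to compound 4 (0.20 log units; within the scatter), not clearly beyond the scatter and, if anything, downward. The estimate for compound 4 is 5000 nM, in the range 1500 nM to 15000 nM.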

Compound 4, solubility: 2000 nM
Compound 4: the middle estimate sits 2.5-fold (0.40 log units) above what was measured; the measured number falls inside the stated range.
By their numbers in this assay, from the lowest: compound 4; then compounds 3 and 1 (each within the scatter of the next); then compound 2.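

In this assay, a six-membered aromatic ring of carbon only, here 3-fluorophenyl, is tolerated at this position next to the ring nitrogen, and a 4.0-fold lower number from compound 3 to compound 4 (0.60 log units; beyond the scatter) separates it from the imidazole, which the furan could not do. Steps of a 5.0-fold lower number from compound 1 to compound 4 (0.70 log units; beyond the scatter) and a 130-fold lower number from compound 2 to compound 4 (2.10 log units; beyond the scatter) set the same group apart from the furan and the oxazole as well, so compound 4 has the lowest number of the four, and the size of the step depends strongly on which five-membered ring it replaces. No measurement is available that would account for any of these steps.

Still open, on these data alone, is whether the step to compound 4 follows from the carbon-only ring or from the fluorine, a question that a plain phenyl group at this position would separate. Also open is how a ring carrying an amine or a carboxylic acid, or a pyridine ring in place of the 3-fluorophenyl, would read in this assay on the shared core, given that the oxazole alone stands high among the compounds shown.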